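The compounds below may be only part of what the source reports. "The series", "measured", "known", "first", "only" and "open" are said of these compounds alone.

Working notes on the series. Among the compounds with values here, in an assay on HL-60 cells for inhibition of glutathione S-transferase P (Homo sapiens) (on this read-out higher numbers stand for weaker inhibition and lower numbers for stronger inhibition), compound 2 `C=C(C)C(=O)c1ccc(OCc2nc(-c3ccccc3)no2)c(C)c1C` gives 1800 nM, the lowest of the two numbers so far; compound 1 `C=C(C)C(=O)c1ccc(OCc2nc(C)no2)c(C)c1C` gives 4000 nM, and the step from compound 1 to compound 2 is a 2.2-fold lower number from compound 1 to compound 2 (0.35 log units; beyond the scatter). Compound 3 `C=C(C)C(=O)c1ccc(OCc2nc(-c3ccc(O)cc3)no2)c(C)c1C` differs from compound 2 by hydroxy in place of hydrogen on an aromatic carbon. Within the data shown here, no measured step bears directly on this change: the only step recorded exchanges methyl for phenyl, not hydrogen for hydroxy, so the size of the step here is not anchored. Absent such a step, compound 3 is expected to sit close to compound 2, with a step of no change at the digits printed from compound 2 to compound 3 (within the scatter) expected in this assay. Compound 3 is therefore estimated at 1800 nM, within a range of 600 nM to 5000 nM.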

Compound 3, half-maximal inhibitory concentration: 3400 nM
For compound 3 the middle estimate is 1.9-fold (0.28 log units) below the measured one; measured number inside the range.
By their numbers in this assay, from the lowest: compounds 2, 3 and 1 (each within the scatter of the next, the first and the last beyond it).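

Hydroxy on this aromatic carbon, para to a large group, gives a 1.9-fold higher number from compound 2 to compound 3 (0.28 log units; within the scatter) in this assay, so adding it here produces no step beyond the scatter. The exchange of methyl for 4-hydroxyphenyl gives a 1.2-fold lower number from compound 1 to compound 3 (0.07 log units; within the scatter), also within the scatter, whereas phenyl in place of methyl gave a step beyond it. No evidence at hand bears on the cause of these steps. The compounds shown leave open how an amine or a methoxy group at this position would read, and whether hydroxy on another carbon of the phenyl ring would read the same.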